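Compound 3 to compound 4: a carbamoyl exchange

The source may report more compounds than this note shows. Statements on the series, on what has been measured and on what is new or still open speak of the compounds shown alone.

In an ADME assay on HEK293 cells (Homo sapiens) for cytotoxicity, with a stated time of 6 h (a higher number here means that more compound is tolerated, a lower number that less compound is tolerated), compound 1 (`CCCCNc1nc(N)nc2ccc(CO)cc12`) gives > 18000 nM, which is a limit. Compound 2 (`CCCCNc1nc(N)nc2ccc(CCc3ccc(N(C)C)cc3)cc12`) gives > 18000 nM, also a limit. Compound 3 (`CCCCNc1nc(N)nc2cccc(CCc3ccccc3)c12`) gives > 25000 nM, again a limit. No order among the three can be read from these results.

Compound 4 (`CCCCNc1nc(N)nc2cccc(C(=O)N(C)C(C)C)c12`) carries isopropyl(methyl)carbamoyl in place of phenethyl on an aromatic carbon. Going by the values given here, no measured step sizes this change. The expected change in this assay is a number no higher from compound 3 to compound 4 (the limit leaves the size open), with no step beyond the scatter expected in either direction. This expectation rests on compound 3 and its limit of > 25000 nM. For compound 4 the estimated value is 25000 nM, with an expected range of 12000 nM to 50000 nM.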

Compound 4, half-maximal cytotoxic concentration: > 25000 nM
Compound 4 was reported as a limit; the forecaster's own chance of this, stated with the estimate: 75%; the middle value sits exactly at the limit.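

Going by these compounds alone, compound 3 and compound 4 both stand only as limits in this assay, so no step between them can be read. The compounds shown leave open whether isopropyl(methyl)carbamoyl in place of phenethyl shifts this read-out at all.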